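Notes on the aryl amide change, compound 2 to compound 3

The source may report more compounds than this note shows. Statements on the series, on what has been measured and on what is new or still open speak of the compounds shown alone.

Compound 1 `CSc1cccc(NC(=O)C2CCCN(C(=O)c3cc(C(F)(F)F)cc(C(F)(F)F)c3)C2)c1` and compound 2 `CC(=O)c1cccc(NC(=O)C2CCCN(C(=O)c3cc(C(F)(F)F)cc(C(F)(F)F)c3)C2)c1` share the same core and differ only in the substituent on the aromatic ring of the anilide. In an ADME assay on PC-3 cells (Homo sapiens) for cytotoxicity, read by WST assay, tested at 100 uM (a higher number here means more inhibition at the concentration tested (going by the name of the read-out), a lower number less inhibition), compound 1 gives 0%. Compound 2 gives 0% in this assay, and the step of no change at the digits printed from compound 1 to compound 2 (within the scatter), acetyl in place of methylsulfanyl on an aromatic carbon, lies within the scatter. Compound 2 therefore stands level with compound 1 at the digits shown, and neither shows inhibition at the concentration tested.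

Compound 3 `O=C(Nc1ccc(Cl)cc1)C1CCCN(C(=O)c2cc(C(F)(F)F)cc(C(F)(F)F)c2)C1` has not yet been measured in this assay. Its change from compound 2 is 4-chlorophenyl in place of 3-acetylphenyl on an amide-type nitrogen. Among the measured compounds shown here, the only measured step that bears on it is no change at the digits printed from compound 1 to compound 2 (within the scatter), a change on the same aromatic ring, and it stayed within the scatter. For the measured compounds named here, nothing measured so far points to a move in this assay when this ring is altered, so no step beyond the scatter is expected. The estimated step is a number 2 percentage points higher from compound 2 to compound 3 (within the scatter). For compound 3 the expected value in this assay is 2%, with a range from -8% to 15%.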

Compound 3, a percentage reported as inhibition, at one concentration (the size of the read-out at that concentration, not a potency): 14%
Compound 3: middle estimate off by 12 percentage points, on the low side, and the stated range covers the measured number.
By their numbers in this assay, from the lowest: compounds 1 and 2 (each within the scatter of the next); then compound 3.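

The aryl group on the amide-type nitrogen can move the read-out in this assay: 4-chlorophenyl in place of 3-acetylphenyl gives a number 14 percentage points higher from compound 2 to compound 3 (beyond the scatter) and 4-chlorophenyl in place of 3-(methylsulfanyl)phenyl gives a number 14 percentage points higher from compound 1 to compound 3 (beyond the scatter). The flat result from the earlier pair therefore holds only for 3-acetylphenyl and 3-(methylsulfanyl)phenyl and does not extend to every aryl group at this place, although the rise is modest and rests on compound 3 alone. Nothing at hand accounts for the step.

Replacing the whole aryl group changes the substituent and its place on the ring together, so the compounds shown do not separate the chlorine from where it sits, and they do not tell whether the step comes from gaining 4-chlorophenyl or from losing the groups of compound 1 and compound 2. On these data alone, how the read-out responds to an unsubstituted phenyl ring, or to a ring carrying an amine or a carboxylic acid, remains open, as does whether any such group would take the read-out further than compound 3 does.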